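Ring size at the aryl amine: pyrrolidine to methylpiperidine

The source may hold more compounds than are shown below. What is called first, only, known or untested is meant among the compounds shown, and "the series" means these compounds.

Measured so far in a functional assay for antagonist activity at transient receptor potential cation channel subfamily V member 1 (Homo sapiens), read by calcium flux; a higher number here means a weaker inhibitor, a lower number a stronger inhibitor:
- compound 1 `CN(C)c1ccc(CNC(=O)Nc2cccc3cnccc23)cc1`: 157 nM
- compound 2 `O=C(NCc1ccc(N2CCCC2)cc1)Nc1cccc2cnccc12`: 5.3 nM
- compound 3 `O=C(NCc1ccc(N2CCCCCCC2)cc1)Nc1cccc2cnccc12`: 4.7 nM

Compound 2 stands second highest of the three numbers in this assay. Its nearest neighbour is compound 3, with a 1.1-fold lower number from compound 2 to compound 3 (0.05 log units; within the scatter); the furthest is compound 1, since a 30-fold lower number from compound 1 to compound 2 (1.47 log units; beyond the scatter).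

Compound 4 `CC1CCN(c2ccc(CNC(=O)Nc3cccc4cnccc34)cc2)CC1` is not yet measured. It differs from compound 2 by 4-methylpiperidin-1-yl in place of pyrrolidin-1-yl on an aromatic carbon.

Among the measured compounds shown here, the steps that bear on this change are those at the same aromatic carbon. Replacing the open-chain dimethylamino of compound 1 by a ring gave large steps: a 30-fold lower number from compound 1 to compound 2 (1.47 log units; beyond the scatter) and a 33-fold lower number from compound 1 to compound 3 (1.52 log units; beyond the scatter). Changing the ring itself, from five-membered to eight-membered, gave a 1.1-fold lower number from compound 2 to compound 3 (0.05 log units; within the scatter). A six-membered ring carrying a methyl sits between those two ring sizes, so no step beyond the scatter is expected in this assay, in either direction.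

Compound 4 is therefore expected to give about 5 nM in this assay, within 2 nM to 13 nM. The step from compound 2 is estimated as a 1.1-fold lower number from compound 2 to compound 4 (0.03 log units; within the scatter).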

Compound 4, half-maximal inhibitory concentration: 9.3 nM
The estimate for compound 4 lay 1.9-fold (0.27 log units) below the measured number; the range from low to high includes it.
By their numbers in this assay, from the lowest: compounds 3, 2 and 4 (each within the scatter of the next); then compound 1.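

In this assay the ring at this aromatic carbon, now six-membered and carrying a methyl, keeps the large gain over the open-chain dimethylamino, with a 17-fold lower number from compound 1 to compound 4 (1.23 log units; beyond the scatter) as the step for 4-methylpiperidin-1-yl. Against the other rings, a 1.8-fold higher number from compound 2 to compound 4 (0.24 log units; within the scatter) and a 2.0-fold higher number from compound 3 to compound 4 (0.30 log units; within the scatter) both stand within the scatter, so the five-membered, substituted six-membered and eight-membered rings of compounds 2, 3 and 4 cannot be told apart here. No measurement at hand bears on the reason for these steps.

Going by these compounds, what the 4-methyl contributes apart from ring size remains open, and piperidin-1-yl itself would address that. Also open, on these data alone, is whether a ring holding a second hetero atom, such as morpholine, would keep the gain over dimethylamino.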